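Removing Bromo from Compound 2: Expected Tolerance in Cells

A few compounds are considered here, and "the series" means these few. Any claim that something is new, unique, unknown or untested is made for them only; others in the source may bear on it.

Three measured compounds share one core. Compound 1 `O=C(NCc1ccc(Cl)cc1)c1cc(-c2ccccc2)nc2ccccc12` carries a (4-chlorobenzyl)amino group on its carbonyl carbon. In an ADME assay on HepG2 2.2.15 cells (Homo sapiens) for cytotoxicity, read by MTT assay, with stated times of 3 days and 7 days (a higher number here means that more compound is tolerated, a lower number that less compound is tolerated), compound 1 gives only a limit, > 20000 nM. Compound 3 `O=C(OCc1ccc(Cl)cc1)c1cc(-c2ccccc2)nc2ccccc12` has (4-chlorobenzyl)oxy in place of (4-chlorobenzyl)amino on the carbonyl carbon. In this assay compound 3 also reaches only a limit, > 20000 nM. The step that the two limits leave unreadable from compound 1 to compound 3 is thus not readable. Compound 2 `O=C(c1cc(-c2cccc(Br)c2)nc2ccccc12)N1CCC(Cc2ccccc2)CC1` likewise stands at a limit, > 20000 nM. All three rest at the limit of > 20000 nM in this assay, at which 3 of the 3 values shown sit.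

Compound 4 `O=C(c1cc(-c2ccccc2)nc2ccccc12)N1CCC(Cc2ccccc2)CC1` differs from compound 2 by hydrogen in place of bromo on an aromatic carbon. No readable measured step bears on this change. Compound 4 is therefore expected to stay at the limit, with an expected step that the limit leaves unreadable from compound 2 to compound 4 of no size beyond the scatter. The estimate for compound 4 is 30000 nM, ranging from 15000 nM to 80000 nM.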

Compound 4, half-maximal cytotoxic concentration: > 20000 nM
Compound 4: a limit, no number; the forecaster's own chance of this, stated with the estimate: 85%; the middle value does not contradict the limit.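

Compound 2 and compound 4 both give only a limit in this assay, so no step between them can be read: the limit of > 20000 nM in this assay, at which 4 of the 4 values shown sit.

The compounds shown leave open whether hydrogen in place of bromo changes how much compound is tolerated.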